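The source may report more compounds than this note shows. Statements on the series, on what has been measured and on what is new or still open speak of the compounds shown alone.

Measured so far in an ADME assay on Huh-7 cells (Homo sapiens) for cytotoxicity, with a stated time of 72 h; a lower number here means that less compound is tolerated, a higher number that more compound is tolerated:
Compound 1, `CC(C)CCn1nc(C2CCCC2)c(O)c(C2=NS(=O)(=O)c3cc(NS(C)(=O)=O)ccc3N2)c1=O`, gives > 1000 nM, which is a limit of this assay rather than a number.
Compound 2, `CS(=O)(=O)Nc1ccc2c(c1)S(=O)(=O)N=C(c1c(O)c(-c3cccs3)nn(CC3CCC3)c1=O)N2`, gives > 1000 nM, again a limit and not a number.

Compound 2 thus stands at the limit of > 1000 nM in this assay, at which 2 of the 2 values shown sit, so nothing separates it from compound 1 on the numbers shown. Compound 3, `CS(=O)(=O)Nc1ccc2c(c1)S(=O)(=O)N=C(c1c(O)c(-c3cccs3)nn(CC3(C(F)(F)F)CCC3)c1=O)N2`, differs from compound 2 by trifluoromethyl in place of hydrogen on a saturated ring carbon. Going by the values given here, no measured step exists for this change, so the expected step that the limit leaves unreadable from compound 2 to compound 3 is none beyond the scatter, because every value so far sits at the limit of > 1000 nM in this assay, at which 2 of the 2 values shown sit. Compound 3 is therefore expected to give about 3000 nM, most likely reported again as a limit, within 800 nM to 20000 nM.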

Compound 3, half-maximal cytotoxic concentration: > 1000 nM
Compound 3 was reported as a limit; the forecaster's own chance of this, stated with the estimate: 85%; the middle value is on the limit's open side.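

No step can be read from compound 2 to compound 3, since both are reported only as limits, not numbers. The compounds shown leave open at what concentration any of them becomes cytotoxic, and whether trifluoromethyl in place of hydrogen changes it.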